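A few compounds are considered here, and "the series" means these few. Any claim that something is new, unique, unknown or untested is made for them only; others in the source may bear on it.

Compound 1 `C=CCN1C(=O)N(Cc2ccccc2)S(=O)(=O)n2cccc21` carries an allyl group on the ring nitrogen of the shared core. In an ADME assay on MT4 cells (Homo sapiens) for cytotoxicity, read by MTT assay, with a stated time of 5 days (a lower number here means that less compound is tolerated, a higher number that more compound is tolerated), compound 1 gives only a limit, > 802000 nM; this is the limit of the measurement and not a number (the limit of > 802000 nM in this assay, at which 1 of the 3 values shown sits). For the measured compounds named here, the other members measured so far are compound 2 `O=C1N(Cc2ccccc2Cl)c2cccn2S(=O)(=O)N1Cc1cccc(F)c1` and compound 3 `O=C1N(Cc2cccc(Cl)c2)c2cccn2S(=O)(=O)N1Cc1cccc(F)c1`. In this assay compound 2 gives 231000 nM, and compound 3 gives 208000 nM; the step of a 1.1-fold lower number from compound 2 to compound 3 (0.05 log units; within the scatter) stays within the scatter. Compound 4 `N#CCN1C(=O)N(Cc2ccccc2)S(=O)(=O)n2cccc21` differs from compound 1 by cyano in place of vinyl on a saturated chain carbon bound to an amide-type nitrogen in a ring. Going by the values given here, no measured step touches this change: the single measured step, 3-chlorophenyl in place of 2-chlorophenyl, concerns a different part of the molecule and moves the number within the scatter. There is therefore no ground for expecting a step beyond the scatter in this assay in either direction, and since compound 1 sits at a limit, compound 4 is expected to return a limit again. The expected step is a number no higher from compound 1 to compound 4 (the limit leaves the size open), essentially flat. Compound 4 is estimated at 800000 nM, with a range from 400000 nM to 1600000 nM.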

Compound 4, half-maximal cytotoxic concentration: 180000 nM
The estimate for compound 4 lay 4.4-fold (0.65 log units) above the measured number, and the stated range ends above it.
By their numbers in this assay, from the lowest: compounds 4, 3 and 2 (each within the scatter of the next). At a limit, above all of these: compound 1.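

In this assay, cyano in place of vinyl on a saturated chain carbon bound to an amide-type nitrogen in a ring gives an at least 4.4-fold lower number from compound 1 to compound 4 (0.64 log units; beyond the scatter). For the compounds shown here, the earlier step concerned only the chlorophenyl group and stayed within the scatter, so this is the first sign that the number responds to a change at this position. The full size of the step stays open, as compound 1 stands at a limit and not a number: the limit of > 802000 nM in this assay, at which 1 of the 4 values shown sits.

The compounds shown leave open whether an amine, a carboxylic acid or a longer chain at this place would move the number as cyanomethyl does. Also open, on these data alone, is whether cyanomethyl would give a similar step on the chlorophenyl-bearing scaffolds of compound 2 and compound 3.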